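A few compounds are considered here, and "the series" means these few. Any claim that something is new, unique, unknown or untested is made for them only; others in the source may bear on it.

Measured so far:
compound 1 `CN(C)c1cccc(Oc2ccc3c(NCCCNCc4ccco4)ccnc3c2)c1` — 16000 nM
compound 2 `COc1ccccc1Oc1ccc2c(NCCCNCc3ccco3)ccnc2c1` — 6500 nM

Both were tested in an ADME assay on HepG2 cells (Homo sapiens) for cytotoxicity, read by luminescence, CellTiter-Glo and ATP content, with a stated time of 72 h; a higher number here means that more compound is needed for the effect, a lower number that less compound is needed. Among the measured compounds shown here, compound 2 gives the lowest of the two numbers there; its nearest neighbour is compound 1, and the single step that connects them, a 2.5-fold lower number from compound 1 to compound 2 (0.39 log units; beyond the scatter), came from swapping one aryl group for another on the oxygen that joins it to the shared core.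

Compound 3 `COc1ccc(-c2ccc3c(NCCCNCc4ccco4)ccnc3c2)cc1` is not yet measured. The change is 4-methoxyphenyl in place of 2-methoxyphenoxy on an aromatic carbon. For the measured compounds named here, only the step from compound 1 to compound 2 bears on this, and only loosely: it also exchanged the aryl group on the shared core, but kept the oxygen link, which compound 3 loses. Since a modest shift followed that earlier exchange, a shift of similar size or none beyond the scatter is expected here, with no clear direction. Compound 3 is therefore expected to give about 6000 nM, between 2000 nM and 20000 nM, an expected step of a 1.1-fold lower number from compound 2 to compound 3 (0.03 log units; within the scatter).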

Compound 3, half-maximal effective concentration: 6000 nM
The estimate for compound 3 equals the measured number at the digits printed; measured number inside the range.
By their numbers in this assay, from the lowest: compounds 3 and 2 (each within the scatter of the next); then compound 1.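

In this assay, 4-methoxyphenyl in place of 2-methoxyphenoxy gives a 1.1-fold lower number from compound 2 to compound 3 (0.03 log units; within the scatter), so at this aromatic carbon of the shared core, the oxygen link and the methoxy placing of compound 2 can both change without a reading beyond the scatter. The other new step, a 2.7-fold lower number from compound 1 to compound 3 (0.43 log units; beyond the scatter), shows that the 3-(dimethylamino)phenoxy group of compound 1 stands apart from the 4-methoxyphenyl group as well as from the 2-methoxyphenoxy group. No measured evidence on the cause of these numbers is available.

This one change alters the oxygen link and the methoxy placing together, so the compounds shown cannot separate the two. Also open, going by these compounds, is how this position responds to a group with no aryl ring, such as a simple amine or a carboxylic acid.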